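Three Limits and an Amino Group Taken Away

The source may hold more compounds than are shown below. What is called first, only, known or untested is meant among the compounds shown, and "the series" means these compounds.

Compound 1, `COc1ccc(/C=C/C(=O)c2cccc(-c3ccc(F)cc3)c2)cc1`: in an assay on A549 cells for inhibition of transcription factor p65 (Homo sapiens), read by fluorescence, with a stated time of 2 h (a higher number here means a weaker inhibitor, a lower number a stronger inhibitor), compound 1 gives > 50000 nM, which is a limit of the assay and not a number.
Compound 2, `COc1ccc(/C=C/C(=O)c2ccc(N)c(-c3ccc(F)cc3)c2)cc1`: compound 2 gives > 50000 nM, again a limit.
Compound 3, `COc1ccc(/C=C/C(=O)c2ccc(N)c(-c3ccc(F)cc3)c2)cc1OC`: compound 3 gives > 50000 nM, also a limit.

The three measured compounds therefore share one position, (the limit of > 50000 nM in this assay, at which 3 of the 3 values shown sit). Between compound 2 and compound 1 the change is hydrogen in place of amino on an aromatic carbon, and the step it made is a step that the two limits leave unreadable from compound 2 to compound 1. Between compound 2 and compound 3 the change is methoxy in place of hydrogen on an aromatic carbon, and that step is a step that the two limits leave unreadable from compound 2 to compound 3. Among the measured compounds shown here, nothing among the measured values sets one compound apart from another.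

Compound 4, `COc1ccc(/C=C/C(=O)c2cccc(-c3ccc(F)cc3)c2)cc1OC`, is not yet measured. It differs from compound 3 by hydrogen in place of amino on an aromatic carbon. The cores of compound 3 and compound 2 differ by methoxy in place of hydrogen on an aromatic carbon. The surroundings of the change from compound 3 to compound 4 match word for word those of the change from compound 2 to compound 1, so it is the same change made on a core that carries one methoxy group more.

The step expected from compound 3 to compound 4 is a step that the limit leaves unreadable from compound 3 to compound 4, set beside the earlier step that the two limits leave unreadable from compound 2 to compound 1. This expectation rests on compound 2, whose value > 50000 nM is a limit, and on the fact that the same change from compound 2 to compound 1 did not move the value off that limit. Compound 4 is accordingly estimated at 80000 nM, with an expected range from 30000 nM to 300000 nM, and most likely only a limit will be reported.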

Compound 4, half-maximal inhibitory concentration: > 50000 nM
Compound 4: no number, only a limit (the forecaster's own chance of this, stated with the estimate: 90%); the middle value does not contradict the limit.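

Among the compounds shown here, neither the step from compound 3 to compound 4 nor the step from compound 1 to compound 4 can be read, and so the result adds no new step. All four compounds share one position, which is a limit and not a number: the limit of > 50000 nM in this assay, at which 4 of the 4 values shown sit.

The compounds shown leave open whether hydrogen in place of amino, or methoxy in place of hydrogen, changes inhibition at all in this assay.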